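The source may report more compounds than this note shows. Statements on the series, on what has been measured and on what is new or still open speak of the compounds shown alone.

Compound 2 `Nc1ncnc2c1nc(NCc1cccc(Cl)c1)n2[C@@H]1O[C@H](CO)[C@@H](O)[C@H]1O` stands lowest among the two numbers shown in an assay on COS-7 cells for inhibition of sodium/nucleoside cotransporter 2 (Homo sapiens), read by scintillation counting, in the presence of a further agent that is not named here (a lower number here means a stronger inhibitor, a higher number a weaker inhibitor), where compound 2 gives 5400 nM. Its nearest neighbour is compound 1 `Cc1ccccc1CNc1nc2c(N)ncnc2n1[C@@H]1O[C@H](CO)[C@@H](O)[C@H]1O`, which in this assay gives 65000 nM. Within the data shown here, the only measured step, a 12-fold lower number from compound 1 to compound 2 (1.08 log units; beyond the scatter), is a large one. Compound 3 `Nc1ncnc2c1ncn2[C@@H]1O[C@H](COC(=O)NCc2ccccc2)[C@@H](O)[C@H]1O` is reported only as a limit in this assay, > 100000 nM. That limit is described as the limit of > 100000 nM in this assay, at which 1 of the 3 values shown sits.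

Compound 4 `Nc1ncnc2c1nc(NCCCc1ccccc1)n2[C@@H]1O[C@H](CO)[C@@H](O)[C@H]1O` differs from compound 2 in one place: phenethyl in place of 3-chlorophenyl on a saturated chain carbon bound to a nitrogen on an aromatic ring. Among the measured compounds shown here, no measured step bears directly on this change; the one step known, a 12-fold lower number from compound 1 to compound 2 (1.08 log units; beyond the scatter), concerns a different swap of aryl group at the same place and says nothing about lengthening the chain or removing the chlorine. Since the 3-chlorophenyl group went with the lowest number shown, its loss in compound 4 is expected to move the number upward, by a 3.7-fold higher number from compound 2 to compound 4 (0.57 log units; beyond the scatter). Compound 4 is therefore estimated at 20000 nM, within a range from 5000 nM to 80000 nM.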

Compound 4, half-maximal inhibitory concentration: 536000 nM
Compound 4: middle estimate off by 27-fold (1.43 log units), on the low side, and the stated range ends below it.
By their numbers in this assay, from the lowest: compound 2; then compound 1; then compound 4.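

In this assay the place on a saturated chain carbon bound to a nitrogen on an aromatic ring proves to respond to more than a swap of aryl group: 3-phenylpropyl in place of 3-chlorobenzyl gives a large step (a 99-fold higher number from compound 2 to compound 4 (2.00 log units; beyond the scatter)). Set against the 2-methylphenyl compound, the same group gives a modest step (an 8.2-fold higher number from compound 1 to compound 4 (0.92 log units; beyond the scatter)), so compound 4 has the highest number of the three exact values. This one change lengthens the chain and removes the chlorine together, and nothing shown gives a reason for either step. The compounds shown leave open how an unsubstituted benzyl group, or a 3-chlorophenyl ring on the longer chain, would read, either of which could part the two changes. As far as these compounds go, an amine on that chain also remains open.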